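Bromo to chloro on a shared core of modest potency

A few compounds are considered here, and "the series" means these few. Any claim that something is new, unique, unknown or untested is made for them only; others in the source may bear on it.

The series rests on one core, seen in compound 1 `CCn1c(/C=C2/C(=O)Nc3ccc(Br)cc32)nc2ccccc21` and compound 2 `Cn1c(/C=C2/C(=O)Nc3ccc(Br)cc32)nc2ccccc21`. In a functional assay on PC-3 cells (Homo sapiens) for cytotoxicity, read by MTT assay, with a stated time of 48 h (a higher number here means a weaker inhibitor, a lower number a stronger inhibitor), compound 1 gives 42700 nM. For compound 2 the result is a limit of the assay rather than a number: in this assay compound 2 gives > 50000 nM. The one measured step, an at least 1.1-fold higher number from compound 1 to compound 2 (0.06 log units; that floor lies within the scatter), concerns the methyl on the chain carbon bound to the aromatic nitrogen and sits partly against the limit (the limit of > 50000 nM in this assay, at which 1 of the 2 values shown sits), so it places compound 2 among the weaker inhibitors shown without fixing its position.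

Compound 3 `Cn1c(/C=C2/C(=O)Nc3ccc(Cl)cc32)nc2ccccc21` differs from compound 2 in one place: chloro in place of bromo on an aromatic carbon. For the measured compounds named here, no measured step touches this halogen exchange, so the expectation leans on where compound 2 stands rather than on a comparable precedent. The step from compound 2 to compound 3 is therefore expected to be small in this assay, with no direction beyond the scatter, as a step that the limit leaves unreadable from compound 2 to compound 3. Compound 3 is estimated at 70000 nM, within a range from 25000 nM to 200000 nM, with a fair chance that only a limit is returned.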

Compound 3, half-maximal inhibitory concentration: > 50000 nM
Compound 3: only a limit was reported; the forecaster's own chance of this, stated with the estimate: 65%; the middle value lies beyond the limit too.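

In this assay compound 3 returns only a limit of the assay, > 50000 nM. For the compounds shown here, no step from compound 2 to compound 3 can be read, so the exchange of bromo for chloro has no readable size: the limit of > 50000 nM in this assay, at which 2 of the 3 values shown sit. The compounds shown leave open how compound 2 and compound 3 truly compare, and whether this halogen exchange changes potency on the shared core at all.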